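Indane-amine replacement on the piperidine of compound 1

This account rests on a few compounds, and the source may have more. Where it says the series, first, only, none or still open, it means among the compounds named here.

Among the compounds with values here, compound 1 `c1ccc(CNCC2CCN(CCCc3c[nH]c4ccc(-n5cnnc5)cc34)CC2)cc1` is measured in a functional assay on CHO cells for activation of 5-hydroxytryptamine receptor 1D (Homo sapiens), read by GTPgammaS binding (a lower number here means a smaller maximal response, a higher number a larger maximal response), and gives 101%, the highest of the two numbers so far. Within the data shown here, compound 2 `c1ccc(C2CCCCN2C2CCN(CCCc3c[nH]c4ccc(-n5cnnc5)cc34)CC2)cc1` gives 65% in this assay, a number lower by a margin beyond the usual scatter; no step between the two is computed, so only the two values themselves are read here.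

Compound 3 `O[C@@H]1Cc2ccccc2[C@H]1NC1CCN(CCCc2c[nH]c3ccc(-n4cnnc4)cc23)CC1` has not yet been measured in this assay. It differs from compound 1 in one place: (2-hydroxy-2,3-dihydro-1H-inden-1-yl)amino in place of (benzylamino)methyl on a saturated ring carbon. The new group keeps an amine bearing a hydrogen and adds a hydroxyl on a five-membered ring fused to the aromatic ring, with two defined stereocentres.

Nothing in the measured pair tells directly how this change will behave. The expectation is a modest drop from the level of compound 1 , within or just beyond the scatter, since the one other variation of this amine seen in compound 2 moved the maximal response downward. The step from compound 1 to compound 3 is estimated as a number 16 percentage points lower from compound 1 to compound 3 (beyond the scatter). Compound 3 is therefore expected to give about 85% in this assay, with a range from 60% to 105%.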

Compound 3, largest response reached (reported as efficacy), in percent of the reference or control that the assay uses: 75%
For compound 3 the middle estimate is 10 percentage points above the measured one, within the range that was stated.
By their numbers in this assay, from the lowest: compounds 2 and 3 (each within the scatter of the next); then compound 1.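

In this assay, within the data shown here, the change from (benzylamino)methyl to (2-hydroxy-2,3-dihydro-1H-inden-1-yl)amino on this saturated ring carbon gives the first step that can be read at this position: a number 26 percentage points lower from compound 1 to compound 3 (beyond the scatter), so the maximal response is sensitive to a single change here. The response is reduced but not lost, and compound 2 at 65% and compound 3 at 75% lie within the scatter of each other, although they carry different groups at this position. No measurement among these compounds accounts for the lower maximal response of compound 3.

This single step changes several features together, so it cannot separate the contribution of the hydroxyl from that of the five-membered ring or the replacement of the (benzylamino)methyl group by an amino group on the ring carbon. From the compounds shown here alone, a 2,3-dihydro-1H-inden-1-ylamino group without the hydroxyl, or one with a methoxy group in its place, would help separate these contributions, while the role of the two defined stereocentres also remains open.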